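The source may report more compounds than this note shows. Statements on the series, on what has been measured and on what is new or still open speak of the compounds shown alone.

Compound 2 `CCc1ccccc1-c1n[nH]c(-c2cccc(F)c2)n1` carries, on the core it shares with compound 1 `C=CCOc1cccc(-c2nc(-c3ccccc3CC)n[nH]2)c1`, a fluoro group where compound 1 has an allyloxy group. In a functional assay on the whole organism (Cricetulus griseus) with Cricetinae gen. sp. as the target (on this read-out lower numbers stand for an effect already at smaller amounts and higher numbers for an effect only at larger amounts of compound), compound 1 gives 5 mg/kg. In this assay compound 2 reaches only a limit of the assay, > 5 mg/kg. The step of a number no lower from compound 1 to compound 2 (the limit leaves the size open) is therefore open in size and points to a number no lower. Compound 3 `CCc1ccccc1-c1n[nH]c(-c2cccc(-c3ccccc3)c2)n1` differs from compound 2 by phenyl in place of fluoro on an aromatic carbon. Among the measured compounds shown here, the only measured step that bears on this is a number no lower from compound 1 to compound 2 (the limit leaves the size open), which ends at the limit of > 5 mg/kg in this assay, at which 1 of the 2 values shown sits, and says nothing about a phenyl group. Compound 3 is nevertheless expected at 5 mg/kg, between 2 mg/kg and 15 mg/kg, an estimated step of a number no higher from compound 2 to compound 3 (the limit leaves the size open).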

Compound 3, dose for half-maximal effect: 10 mg/kg
Estimate against measurement, compound 3: 2.0-fold (0.30 log units) below; low and high end bracket the measured number.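

Phenyl in place of allyloxy on this aromatic carbon gives, in this assay, a 2.0-fold higher number from compound 1 to compound 3 (0.30 log units; within the scatter), so this read-out does not tell these two groups apart at this position. A much larger ring of carbon therefore fits here as well as the allyloxy chain does on this read-out. The steps that start from compound 2 cannot be read, because compound 2 stands at a limit of the assay: the limit of > 5 mg/kg in this assay, at which 1 of the 3 values shown sits.

On these data alone, how fluoro truly compares with phenyl or allyloxy stays open. So does what an amine or a carboxylic acid on this carbon would give.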